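Series notes: aryl ether variation on the hydroxyketone core

The source may hold more compounds than are shown below. What is called first, only, known or untested is meant among the compounds shown, and "the series" means these compounds.

Three compounds of the shared core have numbers in an assay for positive allosteric modulation of metabotropic glutamate receptor 3 (Rattus norvegicus); a lower number here means that less compound is needed, a higher number that more compound is needed for the effect. Compound 1 `Cc1c(OCCCCOc2ccc(C(=O)O)c(F)c2)ccc(C(=O)CC(C)(C)C)c1O` gives 1110 nM. Compound 2 `COc1ccc(C(=O)O)cc1O[C@H](C)COc1ccc(C(=O)CC(C)(C)C)c(O)c1C` gives 1850 nM. Compound 3 `Cc1c(OC[C@@H](C)COc2ccc(C(=O)O)cc2F)ccc(C(=O)CC(C)(C)C)c1O` gives 1300 nM, which is the second highest of the three; its gap to compound 1 and its gap to compound 2 both lie within the scatter, so no order among them is claimed.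

The next compound, compound 4 `COc1ccccc1OC[C@H](C)COc1ccc(C(=O)CC(C)(C)C)c(O)c1C`, differs from compound 3 by 2-methoxyphenyl in place of 4-carboxy-2-fluorophenyl on an oxygen on a saturated carbon. Among the compounds with values here, no pair of measured compounds differs in only one place, so no measured step guides this change. The expectation is a step beyond the scatter toward a higher number, estimated as a 3.5-fold higher number from compound 3 to compound 4 (0.54 log units; beyond the scatter). Compound 4 is therefore expected to give 4500 nM, within a range of 1500 nM to 13000 nM.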

Compound 4, half-maximal effective concentration: "not active" (no number reported)
No number was reported for compound 4; there is nothing to compare the estimate with.
By their numbers in this assay, from the lowest: compounds 1, 3 and 2 (each within the scatter of the next).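

Within the data shown here, compound 4 is reported as not active in this assay with no number, so no step from compound 3 to compound 4 can be read. The compounds shown leave open whether any compound carrying 2-methoxyphenyl in this place gives a number. No supporting data bear on this result.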